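A few compounds are considered here, and "the series" means these few. Any claim that something is new, unique, unknown or untested is made for them only; others in the source may bear on it.

Three measured compounds set the scene. Compound 1 `CCc1ccccc1N(CC(=O)OCc1ccc(OC)cc1)S(=O)(=O)c1ccc(C)cc1` was measured twice in an assay on CHO cells for displacement of a labelled ligand from prostaglandin E2 receptor EP1 subtype (Homo sapiens) (on this read-out higher numbers stand for weaker inhibition and lower numbers for stronger inhibition), and its two readings, 63 nM; 63.1 nM (2 entries), are given in the record (the several entries of compound 1 in this assay, 63 nM; 63.1 nM (2 entries)). Compound 2 `CCc1ccccc1N(Cc1nnc(Cc2ccc(OC)cc2)o1)S(=O)(=O)c1ccc(C)cc1`, which carries a five-membered aromatic ring in its side arm instead of an ester, gives 126 nM; 126 nM (2 entries) in this assay. Compound 3 `Cc1ccc(S(=O)(=O)N(Cc2nnc(Cc3ccc(N(C)C)cc3)o2)c2cccc(Cl)c2C)cc1`, with a differently substituted phenyl ring on the sulfonamide nitrogen and a 4-(dimethylamino)benzyl group on the five-membered ring, gives 12.6 nM, the lowest number of the three shown, while two further entries for it report no single number.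

Compound 4 `COc1ccc(Nc2nnc(CN(c3cccc(Cl)c3C)S(=O)(=O)c3ccc(C)cc3)o2)cc1` is not yet measured. It differs from compound 3 in one place: (4-methoxyphenyl)amino in place of 4-(dimethylamino)benzyl on an aromatic carbon. The aromatic ring of the arm is thus joined to the core directly through a nitrogen rather than through a methylene, and it gains a hydrogen-bond donor. Going by the values given here, no measured pair in this set shows such a swap, so its effect can only be guessed. The expectation is a modest loss, a step from compound 3 to compound 4 of a 3.2-fold higher number from compound 3 to compound 4 (0.50 log units; beyond the scatter) in this assay, which may not exceed the usual scatter. Compound 4 is therefore estimated at 40 nM in this assay, within a range of 8 nM to 200 nM.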

Compound 4, half-maximal inhibitory concentration: 31.6 nM
Compound 4: middle estimate off by 1.3-fold (0.10 log units), on the high side, within the range that was stated.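

In this assay, going by these compounds alone, putting (4-methoxyphenyl)amino in place of 4-(dimethylamino)benzyl on the carbon of the five-membered aromatic ring that lies next to the ring nitrogen and next to the ring oxygen gives a 2.5-fold higher number from compound 3 to compound 4 (0.40 log units; beyond the scatter), the first step in this set that changes one place only. The step is beyond the usual scatter but modest, so this position still accepts an arm with an aromatic ring when a nitrogen replaces the methylene as the link to the core, and when the arm holds 1 hydrogen-bond donor where the old one held 0. Two features change together in this swap, the link and the group on the arm's aromatic ring, and nothing in the data shown explains the step or assigns it to either feature.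

An arm named (4-(dimethylamino)phenyl)amino on the same core would keep the old ring group with the new link, and so would help to tell those two features apart. From the compounds shown here alone, it also remains open how this position responds to an arm with no aromatic ring at all, such as a morpholine or a short chain ending in a carboxylic acid.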